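Swapping the Amine Substituent on a Shared Core

The source may report more compounds than this note shows. Statements on the series, on what has been measured and on what is new or still open speak of the compounds shown alone.

Of the compounds shown here, two built on a shared core have been measured in an assay on cell membranes for displacement of a labelled ligand from corticotropin-releasing factor receptor 1 (Rattus norvegicus); a higher number here means a weaker inhibitor, a lower number a stronger inhibitor. Compound 1, `COCC(COC)Nc1nc(C)nc2c(-c3ccc(OC)cc3C)c(C)nn12`, gives 9.7 nM in this assay, the higher of the two numbers and thus the weaker inhibitor of the pair. Compound 2, `CCN(CC)c1nc(C)nc2c(-c3c(C)cc(OC)cc3OC)c(C)nn12`, differs from it in more than one place and gives 1.2 nM in this assay, a gap that lies beyond the usual scatter. The two structures differ at several positions at once, so the separate contribution of each change cannot be read from this pair.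

Compound 3, `CCCN(CCC#N)c1nc(C)nc2c(-c3ccc(OC)cc3C)c(C)nn12`, has not yet been measured in this assay. Its difference from compound 1 is (2-cyanoethyl)(propyl)amino in place of (2-methoxy-1-(methoxymethyl)ethyl)amino on an aromatic carbon. The group that enters carries no hydrogen-bond donor, while the group that leaves carries one. Compound 2, with 1.2 nM, shows that a strong inhibitor can carry a group lacking a donor, yet its other changes cloud the comparison. A modest gain is expected, with the step of a 1.9-fold lower number from compound 1 to compound 3 (0.29 log units; within the scatter) running toward a lower number. Compound 3 is expected to give about 5 nM in this assay, plausibly from 1.5 nM to 15 nM.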

Compound 3, half-maximal inhibitory concentration: 2.16 nM
Beside the measured number, compound 3's estimate is 2.3-fold (0.36 log units) above it, within the range that was stated.
By their numbers in this assay, from the lowest: compounds 2 and 3 (each within the scatter of the next); then compound 1.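

In this assay, for the compounds shown here, the single change of (2-cyanoethyl)(propyl)amino in place of (2-methoxy-1-(methoxymethyl)ethyl)amino gives a 4.5-fold lower number from compound 1 to compound 3 (0.65 log units; beyond the scatter). Going by these compounds alone, this is the first reading of one change at this position on the shared core, something the earlier pair could not offer, as its two members differ in several places at once. It shows that, with the rest of the structure held fixed and the heavy-atom count unchanged, a group with no hydrogen-bond donor can replace one that has a donor and the inhibitor becomes stronger, while no measurement at hand bears on what lies behind the gain.

The two groups differ at once in the donor, the ether oxygens and the nitrile, so this one step cannot show which of these features matters. A dipropylamino group on the same core would test the nitrile on its own, and a (2-cyanoethyl)amino group, which keeps a hydrogen on the nitrogen, would help to separate the effect of the donor from that of the nitrile.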